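Swapping carbamoyl for nitro in a cytotoxicity test

The source may hold more compounds than are shown below. What is called first, only, known or untested is meant among the compounds shown, and "the series" means these compounds.

Three related compounds have been tested in an ADME assay on TZM cells (Homo sapiens) for cytotoxicity, read by XTT assay, with a stated time of 4 days; on this read-out lower numbers stand for higher toxicity in this test and higher numbers for lower toxicity in this test. Compound 1 `Cc1cc(N)cc(C)c1Oc1cc(Nc2ccc(C#N)cc2)c(N)cc1C(F)(F)F` gives a true number there, 15800 nM. Compound 2 `CNC(=O)c1cc2ncn(-c3ccc(C#N)cc3)c2cc1Oc1c(C)cc(CCC#N)cc1C` gives > 890000 nM, which is a limit of the test and not a number. Compound 3 `Cc1cc(/C=C/C#N)cc(C)c1Oc1cc(Nc2ccc(C#N)cc2)c(N)cc1C(N)=O` gives > 23600 nM, which is also a limit and not a number. Compound 3 therefore has no exact place on the scale.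

Compound 4 `Cc1cc(/C=C/C#N)cc(C)c1Oc1cc(Nc2ccc(C#N)cc2)c(N)cc1[N+](=O)[O-]` keeps the rest of compound 3 but has nitro in place of carbamoyl on an aromatic carbon. For the measured compounds named here, no pair of measured compounds shows this swap alone, so any expectation here is rough. Going by the values given here, the best available anchor is compound 1 at 15800 nM, the only true number in the set. An expected step of an at least 1.1-fold lower number from compound 3 to compound 4 (0.07 log units; that floor lies within the scatter) would be small, probably no larger than the usual scatter, and would lean toward lower numbers if it were real. For compound 4 the estimated value in this assay is 20000 nM, with an expected range from 6000 nM to 60000 nM.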

Compound 4, half-maximal cytotoxic concentration: > 24400 nM
Compound 4 ended at the assay's limit; the forecaster's own chance of this, stated with the estimate: 40%; at least 1.2-fold (0.08 log units) between middle value and limit.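

Compound 3 and compound 4 each end at a limit of this assay and not at a true number, so the swap of carbamoyl for nitro between them cannot be read as a step. The compounds shown leave open both the direction and the size of this swap's effect.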